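Series notes: dihydrobenzofuran acetic acids at the free fatty acid receptor

The source may hold more compounds than are shown below. What is called first, only, known or untested is meant among the compounds shown, and "the series" means these compounds.

Measured compounds:
- compound 1, `O=C(O)CC1COc2cc(OCc3nnc(-c4ccccc4)o3)ccc21`: 1.54%
- compound 2, `O=C(O)CC1COc2cc(OCc3ncc(-c4ccccc4)o3)ccc21`: 2.34%
- compound 3, `Cc1nc(-c2cc3ccccc3o2)sc1COc1ccc2c(c1)OCC2CC(=O)O`: 14.8%

All three were run in a functional assay on CHO cells for agonist activity at Free fatty acid receptor 1 (Homo sapiens), read by FLIPR and calcium flux, tested at 100 nM; a higher number here means a stronger effect of the compound at the concentration tested, a lower number a weaker effect. Compound 1 and compound 2 both give small readings, and the two numbers lie within the usual scatter of each other, so nothing separates them. Compound 3 stands apart: of the three numbers it is the highest, with its nearest neighbour, compound 2, a number lower by more than the scatter, and compound 1 further below again, also beyond the scatter. No two of the measured compounds differ in only one place, so no single-change step can be read off this set.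

Compound 4, `Cc1nc(-c2ccccc2C(F)(F)F)sc1COc1ccc2c(c1)OCC2CC(=O)O`, has not yet been measured. It differs from compound 3 in one place:
2-(trifluoromethyl)phenyl in place of 1-benzofuran-2-yl on an aromatic carbon
With no measured step of this kind in the set, the size and direction of the change in this assay are open. The expectation is a modest drop from compound 3 to compound 4, at the edge of the scatter, a number 6.8 percentage points lower from compound 3 to compound 4 (within the scatter). For compound 4 the estimated reading in this assay is 8%, with a range from 1% to 28%.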

Compound 4, a percentage reported as activity, at one concentration (the size of the read-out at that concentration, not a potency): 7.76%
Compound 4: the middle estimate sits 0.2 percentage points above what was measured; the range from low to high includes it.
By their numbers in this assay, from the lowest: compounds 1, 2, 4 and 3 (each within the scatter of the next, the first and the last beyond it).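

In this assay, among these compounds, the step of a number 7 percentage points lower from compound 3 to compound 4 (within the scatter) is the first single-place change that can be read. It replaces 1-benzofuran-2-yl with 2-(trifluoromethyl)phenyl on the aromatic carbon of the five-membered aromatic ring with 1 nitrogen and 1 sulfur, next to the ring nitrogen and the ring sulfur. The step lies within the scatter, so at this position the readings do not separate a fused pair of aromatic rings bearing a hydrogen-bond acceptor from a single carbon-only aromatic ring bearing trifluoromethyl, and this one pair gives no sign that either group is preferred. No measurement available here bears on the reason for the size of this step.

From the compounds shown here alone, what a plain phenyl, a pyridyl or a group with an amine such as morpholine would read at this same aromatic carbon remains open, as does whether replacing the neighbouring methyl group with a longer chain would move the reading beyond the scatter. Each reading also gives the size of the effect at one concentration, so the potency of these compounds and any potency gap between them remain open.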